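The compounds below may be only part of what the source reports. "The series", "measured", "known", "first", "only" and "open" are said of these compounds alone.

Compounds measured so far: compound 1 `O=C(O)Cc1sc(Nc2ccccc2)nc1-c1ccccc1` gives 1500 nM in an in vitro functional assay on HEK285-7 cells for antagonist activity at prostaglandin D2 receptor 2 (Homo sapiens), read by BRET and beta-arrestin recruitment; a lower number here means a stronger inhibitor, a higher number a weaker inhibitor; compound 2 `O=C(O)Cc1sc(Nc2ccccc2)nc1-c1ccc(F)cc1` gives 1300 nM; compound 3 `COc1ccccc1Nc1nc(-c2ccc(F)cc2)c(CC(=O)O)s1` gives 2100 nM.

Compound 1 and compound 2 differ in one place, (hydrogen in place of fluoro on an aromatic carbon), and the step of a 1.2-fold lower number from compound 1 to compound 2 (0.06 log units; within the scatter) is small. From compound 2 to compound 3 the change is methoxy in place of hydrogen on an aromatic carbon, and the step it made was a 1.6-fold higher number from compound 2 to compound 3 (0.21 log units; within the scatter). The unmeasured compound 4 `COc1ccc(Nc2nc(-c3ccccc3)c(CC(=O)O)s2)cc1` arises from compound 1 by methoxy in place of hydrogen on an aromatic carbon. This is the same kind of change, not the same: in compound 3 the methoxy sits ortho to a large group, in compound 4 para to a large group. Since the earlier step stayed within the scatter, the step from compound 1 to compound 4 in this assay is expected to be about as modest, a 1.3-fold higher number from compound 1 to compound 4 (0.12 log units; within the scatter), resting on a 1.6-fold higher number from compound 2 to compound 3 (0.21 log units; within the scatter) alone. Compound 4 is therefore estimated at 2000 nM, between 900 nM and 4500 nM.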

Compound 4, half-maximal inhibitory concentration: 1500 nM
The estimate for compound 4 lay 1.3-fold (0.12 log units) above the measured number; the range from low to high includes it.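

In this assay, methoxy in place of hydrogen on the aromatic carbon gave no change at the digits printed from compound 1 to compound 4 (within the scatter). Set beside the earlier step, this gives no sign that the core alters the outcome of the change: the same change on two cores in this assay, a 1.6-fold higher number (0.21 log units; within the scatter) from compound 2 to compound 3 and no change at the digits printed (within the scatter) from compound 1 to compound 4, 1.6-fold (0.21 log units) apart, within the scatter of two such steps. Among these compounds, this rests on only two pairs, however, and the methoxy does not sit in the same place in them, para to a large group in compound 4 but elsewhere in compound 3, so it does not show that the change would carry over to other cores or positions.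

The compounds shown leave open what a trifluoromethyl, a nitrile or an amine would do on this ring. They also leave open whether a longer chain bearing the carboxylic acid would move the number.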